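This account rests on a few compounds, and the source may have more. Where it says the series, first, only, none or still open, it means among the compounds named here.

Working notes on the series in a toxicity assay on GES1 cells (Homo sapiens) for inhibition, read by MTT assay, with a stated time of 72 h; a lower number here means a stronger inhibitor, a higher number a weaker inhibitor.

Three members of the series carry a result so far. Compound 1 `CCc1cc(N2CC[C@@H](C)[C@@H](N(C)c3ncnc4[nH]ccc34)C2)n2ncnc2n1` reaches only the limit of the assay, reported as > 100000 nM; this is a limit, not a number (the limit of > 100000 nM in this assay, at which 1 of the 3 values shown sits). Compound 2 `Cc1cc(N2CC[C@@H](C)[C@@H](N(C)c3ncnc4[nH]ccc34)C2)n2nc(SCc3cc(Cl)ccc3Cl)nc2n1` gives 87500 nM. Compound 3 `Cc1cc(N2CC[C@@H](C)[C@@H](N(C)c3ncnc4[nH]ccc34)C2)n2nc(SCCc3ccccc3)nc2n1` gives 66200 nM, the lowest of the two numbers, with compound 2 nearest to it. Within the data shown here, the one remaining value, that of compound 1, is the limit already described. Among the measured compounds shown here, the single measured step, a 1.3-fold lower number from compound 2 to compound 3 (0.12 log units; within the scatter), lies within the scatter, so the two numbers cannot be put in order.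

Compound 4 `Cc1cc(N2CC[C@@H](C)[C@@H](N(C)c3ncnc4[nH]ccc34)C2)n2nc(SCc3ccc(F)cc3)nc2n1` carries the change 4-fluorophenyl in place of benzyl on a saturated chain carbon bound to a sulfur on the same shared core. For the measured compounds named here, the only step that bears on it, a 1.3-fold lower number from compound 2 to compound 3 (0.12 log units; within the scatter), left the number essentially unchanged, so no movement beyond the scatter is expected in this assay in either direction. Compound 4 is therefore expected near 70000 nM, between 35000 nM and 140000 nM. The expected step is a 1.1-fold higher number from compound 3 to compound 4 (0.02 log units; within the scatter), with a real chance that only a limit is reported.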

Compound 4, half-maximal inhibitory concentration: 12300 nM
The estimate for compound 4 lay 5.7-fold (0.76 log units) above the measured number; the measured number lies below the stated range.
By their numbers in this assay, from the lowest: compound 4; then compounds 3 and 2 (each within the scatter of the next). At a limit, above all of these: compound 1.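

In this assay, the group on the saturated chain carbon bound to a sulfur now moves the number beyond the scatter: there is a 5.4-fold lower number from compound 3 to compound 4 (0.73 log units; beyond the scatter), and a 7.1-fold lower number from compound 2 to compound 4 (0.85 log units; beyond the scatter). The earlier step at this place, a 1.3-fold lower number from compound 2 to compound 3 (0.12 log units; within the scatter), gave no such reading, so this position is not silent in this assay, and 4-fluorophenyl gives the lowest number among those shown. Nothing measured here accounts for the shift.

Cut one bond further out, the change reads phenethyl to 4-fluorobenzyl, so the fluorine and the chain length change together and the compounds shown do not separate them. From the compounds shown here alone, a plain benzyl on the sulfur would separate those two changes, and it remains open how a 4-chlorobenzyl or an amine-bearing chain at this place would read.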